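Swapping the Amide Substituent on Compound 2

The source may report more compounds than this note shows. Statements on the series, on what has been measured and on what is new or still open speak of the compounds shown alone.

For the measured compounds named here, in a functional assay on EBC-1 cells (Homo sapiens) for antiproliferative activity, with a stated time of 72 h (a lower number here means a stronger inhibitor, a higher number a weaker inhibitor), compound 2 (`O=C(NCC1CCCCN1)c1ccc(-c2cc(F)c3ncc(Cc4ccc5ncccc5c4)n3c2)cc1F`) gives 277 nM, the lower of the two numbers so far, while compound 1 (`CN1CCN(C(=O)c2ccc(-c3cc(F)c4ncc(Cc5ccc6ncccc6c5)n4c3)cc2F)CC1`) gives 869 nM. Compound 3 (`O=C(NCc1cc(F)cc(F)c1)c1ccc(-c2cc(F)c3ncc(Cc4ccc5ncccc5c4)n3c2)cc1F`) keeps the shared core and the amide link of compound 2 but carries 3,5-difluorophenyl in place of piperidin-2-yl on a saturated chain carbon bound to an amide-type nitrogen. Going by the values given here, only one measured step bears on this change, and only loosely: a 3.1-fold lower number from compound 1 to compound 2 (0.50 log units; beyond the scatter), a modest move beyond the scatter that involved a different pair of groups on the carbonyl carbon. It gives a rough size, not a direction. With compound 2 at 277 nM as the lower number, a modest rise is expected, though a fall cannot be excluded. The expected change is a 1.5-fold higher number from compound 2 to compound 3 (0.18 log units; within the scatter). For compound 3 the estimated value is 420 nM, with an expected range of 130 nM to 1300 nM.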

Compound 3, half-maximal inhibitory concentration: 53.6 nM
Estimate against measurement, compound 3: 7.8-fold (0.89 log units) above; measured number below the stated range.
By their numbers in this assay, from the lowest: compound 3; then compound 2; then compound 1.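

At the saturated chain carbon bound to an amide-type nitrogen, 3,5-difluorophenyl in place of piperidin-2-yl gives a 5.2-fold lower number from compound 2 to compound 3 (0.71 log units; beyond the scatter) in this assay, so this position does not depend on the non-aromatic ring or its hydrogen-bond donor and acceptor for activity in these compounds. Set against the 4-methylpiperazin-1-yl amide, (3,5-difluorobenzyl)amino on the carbonyl carbon gives a 16-fold lower number from compound 1 to compound 3 (1.21 log units; beyond the scatter), the widest span among the three compounds and a sign that this amide substituent can shift the number substantially. No measurement offered here accounts for the difference.

A plain benzyl group would show whether the two fluorine atoms contribute or the carbon-only aromatic ring alone suffices. A pyridine ring, or a longer chain between the amide nitrogen and the ring, would show how much of the change this position tolerates.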